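The compounds below may be only part of what the source reports. "The series", "measured", "known", "first", "only" and "open" are said of these compounds alone.

Measured so far:
- compound 1 `CCOC(=O)/C=C/c1ccc2c(c1)C(=O)C(=O)N2Cc1ccc(OC)cc1`: 30 nM
- compound 2 `COC(=O)/C=C/c1ccc2c(c1)/C(=N/O)C(=O)N2Cc1ccc(OC)cc1`: 9110 nM

In a functional assay on Jurkat cells (Homo sapiens) for antiproliferative activity, read by MTT assay, with a stated time of 48 h (a lower number here means a stronger inhibitor, a higher number a weaker inhibitor), compound 1 gives 30 nM. In this assay, within the data shown here, compound 2 gives 9110 nM, the higher of the two numbers; the gap between the two values is far beyond the usual scatter, and compound 1 is the only comparison available, differing from compound 2 in more than one place, so the two values say only that compound 2 is the much weaker inhibitor of the pair.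

Compound 3 `COC(=O)/C=C/c1ccc2c(c1)/C(=N/O)C(=O)N2Cc1ccc(Br)cc1` has not been measured. Against compound 2 it shows one change, (bromo in place of methoxy on an aromatic carbon), a swap of one group for another on the benzyl ring, para to a large group. No measured pair in the series isolates such a swap, so there is no shown step to lean on. The expectation is that this assay changes little beyond the scatter in either direction, with the value of compound 2 as the anchor. The estimated step of a 1.5-fold lower number from compound 2 to compound 3 (0.18 log units; within the scatter) is small and uncertain in sign. Compound 3 is therefore expected to give about 6000 nM, within a range of 1500 nM to 25000 nM.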

Compound 3, half-maximal inhibitory concentration: 5860 nM
For compound 3 the middle estimate is 1.0-fold (0.01 log units) above the measured one, and the stated range covers the measured number.
By their numbers in this assay, from the lowest: compound 1; then compounds 3 and 2 (each within the scatter of the next).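

In this assay, among these compounds, going from 4-methoxybenzyl to 4-bromobenzyl gives a 1.6-fold lower number from compound 2 to compound 3 (0.19 log units; within the scatter), and this is the first step that isolates a single place. At this position, on an aromatic carbon para to a large group, the methoxy can therefore be exchanged for a bromo on the core of compound 2 without the values separating beyond the scatter, even though the exchange removes a hydrogen-bond acceptor and one heavy atom. No measurement shown here offers an explanation for this result.

This single pair does not show how far the position tolerates other groups, such as an amine, a carboxylic acid or a longer chain in place of the bromo or the methoxy. It also leaves open whether bromo in place of methoxy would read the same on the core of compound 1, where the value in this assay lies in a very different range and the surrounding structure is not the same.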